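Hydroxy for bromo on the pendant ring: an expectation

A few compounds are considered here, and "the series" means these few. Any claim that something is new, unique, unknown or untested is made for them only; others in the source may bear on it.

Three compounds sharing one core have numbers in a functional assay on RAW264.7 cells (Mus musculus) for inhibition; a higher number here means a weaker inhibitor, a lower number a stronger inhibitor. Compound 1 `O=C1/C(=C/c2cccc(F)c2)CCc2cc(O)ccc21` gives 1230 nM, compound 2 `O=C1/C(=C/c2cccc(OC(F)(F)F)c2)CCc2cc(O)ccc21` gives 520 nM, and compound 3 `O=C1/C(=C/c2cccc(Br)c2)CCc2cc(O)ccc21` gives 1140 nM. Compound 3 stands second highest of the three: its number and that of compound 1 lie within the scatter of each other, as a 1.1-fold lower number from compound 1 to compound 3 (0.03 log units; within the scatter) shows, while a 2.2-fold higher number from compound 2 to compound 3 (0.34 log units; beyond the scatter) is a modest rise and a 2.4-fold lower number from compound 1 to compound 2 (0.37 log units; beyond the scatter) a modest fall. Compound 4 `O=C1/C(=C/c2cccc(O)c2)CCc2cc(O)ccc21` differs from compound 3 by hydroxy in place of bromo on an aromatic carbon. Within the data shown here, no measured step involves a hydroxy at this position, so none bears directly on the change; the halogen swap from compound 1 to compound 3 stayed within the scatter, and only the trifluoromethoxy group moved the number. Because a 1.1-fold lower number from compound 1 to compound 3 (0.03 log units; within the scatter) was flat, the step is expected to be small, a 1.1-fold higher number from compound 3 to compound 4 (0.06 log units; within the scatter), with wide uncertainty in either direction. Compound 4 is therefore estimated at 1300 nM, between 450 nM and 3800 nM.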

Compound 4, half-maximal inhibitory concentration: 3510 nM
Estimate against measurement, compound 4: 2.7-fold (0.43 log units) below; the range from low to high includes it.
By their numbers in this assay, from the lowest: compound 2; then compounds 3 and 1 (each within the scatter of the next); then compound 4.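

At this position the two halogens had left the number flat in this assay, but hydroxy raises it: a 3.1-fold higher number from compound 3 to compound 4 (0.49 log units; beyond the scatter) and a 2.9-fold higher number from compound 1 to compound 4 (0.46 log units; beyond the scatter) both lie beyond the scatter, so the position is not indifferent to what it carries. Together with trifluoromethoxy, hydroxy marks the two ends of the series, with a 6.8-fold higher number from compound 2 to compound 4 (0.83 log units; beyond the scatter) as the largest step among these compounds, and compound 4 is the weakest inhibitor of the four. Nothing available here explains why the hydroxy compound falls behind the halogen compounds.

The compounds shown leave open whether the rise belongs to hydroxy alone or would also appear with methoxy or an amine at this position. They also leave open whether a carboxylic acid there would raise the number further.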